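Acid tether variants on the naphthylethoxy pyrazolylmethyl phenyl series

The source may hold more compounds than are shown below. What is called first, only, known or untested is meant among the compounds shown, and "the series" means these compounds.

Measured so far:
compound 1 `O=C(O)/C=C/c1ccc(Cn2cccn2)cc1OCCc1ccc2ccccc2c1` — 2900 nM
compound 2 `COc1ccc(/C=C/C(=O)O)c(OCCC2(C)CCc3c(C)c(O)c(C)c(C)c3O2)c1` — > 10000 nM
compound 3 `O=C(O)C#Cc1ccc(Cn2cccn2)cc1OCCc1ccc2ccccc2c1` — > 10000 nM

All three values come from an assay on CHO cells for displacement of a labelled ligand from prostaglandin E2 receptor EP1 subtype (Mus musculus), read by scintillation counting; a higher number here means a weaker inhibitor, a lower number a stronger inhibitor. Compound 1 gives 2900 nM. For compound 2 the value > 10000 nM is a limit of the assay, not a number. For compound 3 the value > 10000 nM is likewise a limit of the assay and not a number; of the three values shown, it is one of the two that sit at the limit of > 10000 nM in this assay, at which 2 of the 3 values shown sit, so compound 3 stands at the weak edge of what this assay can report.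

For the measured compounds named here, the one single-point step measured is an at least 3.4-fold higher number from compound 1 to compound 3 (0.53 log units; beyond the scatter), the exchange of the 2-carboxyethenyl tether for 2-carboxyethynyl. It bears directly on the next step, since compound 4 `O=C(O)COc1ccc(Cn2cccn2)cc1OCCc1ccc2ccccc2c1` again alters only the acid-bearing tether: carboxymethoxy in place of 2-carboxyethynyl on an aromatic carbon.

Because compound 3 is only a limit, the step from compound 3 to compound 4 cannot be tied to a known number. The measured step from compound 1 shows that the tether can move this assay by at least a modest amount, so a change of similar size in either direction is plausible. For compound 4 the expected step is an at least 1.6-fold lower number from compound 3 to compound 4 (0.22 log units; that floor lies within the scatter). On balance the expectation is that compound 4 lands near 6000 nM, with a range from 1000 nM to 30000 nM, and a fair chance that this assay reports only a limit again.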

Compound 4, inhibition constant: > 10000 nM
Compound 4 was reported as a limit; the forecaster's own chance of this, stated with the estimate: 40%; middle value at least 1.6-fold (0.22 log units) from the limit.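

Replacing 2-carboxyethenyl with carboxymethoxy on this aromatic carbon, para to the (1H-pyrazol-1-yl)methyl group, gives an at least 3.4-fold higher number from compound 1 to compound 4 (0.53 log units; beyond the scatter) in this assay, so the loss seen with 2-carboxyethynyl is not confined to that one replacement. Compound 4 gives > 10000 nM in this assay, which is a limit of the assay and not a number, and the step between compound 3 and compound 4 cannot be read. Among compounds 1, 3 and 4, only the 2-carboxyethenyl tether yields a number, with compound 1 at 2900 nM in this assay, and the series now sits mainly at the weak edge of the range: the limit of > 10000 nM in this assay, at which 3 of the 4 values shown sit.

Going by these compounds, how far compound 3 and compound 4 lie beyond that edge, and whether they differ from each other, remains unknown. Also open, on these data alone, is how a saturated 2-carboxyethyl chain, or a longer chain ending in a carboxylic acid, would compare with the 2-carboxyethenyl tether at this position.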